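The compounds below may be only part of what the source reports. "The series", "measured", "known", "first", "only" and "open" are said of these compounds alone.

Compound 3 `Cc1cccc(-n2nncc2CN2C(=O)C3(C(C#N)=C(N)Oc4c(N)cc5nc6ccccc6nc5c43)c3ccccc32)c1` was tested in a functional assay on MCF7 cells (Homo sapiens) for antiproliferative activity, read by MTT assay, with a stated time of 48 h; on this read-out lower numbers stand for stronger inhibition and higher numbers for weaker inhibition. For compound 3 the result is only a limit of the assay, > 50000 nM, not a measured number. Compound 4 `N#CC1=C(N)Oc2c(N)cc3nc4ccccc4nc3c2C12C(=O)N(Cc1cnnn1-c1cc(Cl)ccc1Cl)c1ccccc12` differs from compound 3 in a single place: 2,5-dichlorophenyl in place of 3-methylphenyl on an aromatic nitrogen. For the measured compounds named here, no measured pair shows this exact change. Going by the values given here, the one single-place step available, a step that the two limits leave unreadable from compound 1 to compound 2, cannot be read in size. Compound 1 `N#CC1=C(N)Oc2c(c3nc4ccccc4nc3c3ccccc23)C12C(=O)N(Cc1cnnn1-c1cc(Cl)ccc1Cl)c1ccccc12` gives in this assay only a limit, > 50000 nM. Compound 2 `N#CC1=C(N)Oc2c(c3nc4ccccc4nc3c3ccccc23)C12C(=O)N(Cc1cnnn1-c1ccc(Cl)c(Cl)c1)c1ccccc12` likewise gives only a limit, > 50000 nM. Among the compounds with values here, every value so far sits at the limit of > 50000 nM in this assay, at which 3 of the 3 values shown sit. Because compound 1, which already carries the 2,5-dichlorophenyl group, gives > 50000 nM, compound 4 is expected to stay at the limit as well, with an estimated step that the limit leaves unreadable from compound 3 to compound 4. Compound 4 is estimated at 70000 nM, with a range from 15000 nM to 300000 nM.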

Compound 4, half-maximal inhibitory concentration: 33200 nM
Estimate against measurement, compound 4: 2.1-fold (0.32 log units) above, within the range that was stated.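

Compound 4 is the only compound shown with a measured number in this assay rather than a limit of the assay. Placing 2,5-dichlorophenyl on the aromatic nitrogen in place of 3-methylphenyl gives an at least 1.5-fold lower number from compound 3 to compound 4 (0.17 log units; that floor lies within the scatter), so the true change could be slight or larger. Activity remains weak across the compounds shown, and most give no number: the limit of > 50000 nM in this assay, at which 3 of the 4 values shown sit.

From the compounds shown here alone, the true value of compound 3 stays unknown, which leaves the real size of this step open. Also open, going by these compounds, is how this position would respond to a phenyl ring bearing an amine or a carboxylic acid, or to a longer chain in place of the ring.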